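Varying the nitrogen substituent of the shared core

This account rests on a few compounds, and the source may have more. Where it says the series, first, only, none or still open, it means among the compounds named here.

In an assay on Prostate gland for inhibition of steroid 5-alpha-reductase (Rattus norvegicus) (on this read-out higher numbers stand for weaker inhibition and lower numbers for stronger inhibition), compound 1 `CCCCCCCn1ccc2cc(/C(C)=C/C(=O)Nc3ccccc3OCCCC(=O)O)ccc21` gives 120 nM. Compound 2 `C/C(=C\C(=O)Nc1ccccc1OCCCC(=O)O)c1ccc2c(ccn2CC(C)C)c1` gives 160 nM, and the step of a 1.3-fold higher number from compound 1 to compound 2 (0.12 log units; within the scatter) stays within the scatter. Compound 3 `CCCCCC(CCCCC)n1ccc2cc(/C(C)=C/C(=O)Nc3ccccc3OCCCC(=O)O)ccc21` gives 25 nM, the lowest number of the three, with a 4.8-fold lower number from compound 1 to compound 3 (0.68 log units; beyond the scatter) and a 6.4-fold lower number from compound 2 to compound 3 (0.81 log units; beyond the scatter) both beyond the scatter. Compound 4 `CCC(c1ccccc1)n1ccc2cc(/C(C)=C/C(=O)Nc3ccccc3OCCCC(=O)O)ccc21` carries 1-phenylpropyl in place of 1-pentylhexyl on an aromatic nitrogen. Among the compounds with values here, no measured step exchanges one 1-substituted group for another; the two steps that bear on it show that the 1-pentylhexyl group gave the lowest number while heptyl and isobutyl gave higher ones. The 1-phenylpropyl group keeps the substitution at the first chain carbon but has fewer heavy atoms, so a modestly higher number is expected, a 2.0-fold higher number from compound 3 to compound 4 (0.30 log units; within the scatter). Compound 4 is estimated at 50 nM, with a range from 20 nM to 150 nM.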

Compound 4, half-maximal inhibitory concentration: 19 nM
Compound 4: middle estimate off by 2.6-fold (0.42 log units), on the high side, outside the stated range (below it).
By their numbers in this assay, from the lowest: compounds 4 and 3 (each within the scatter of the next); then compounds 1 and 2 (each within the scatter of the next).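

On the aromatic nitrogen, a group with one six-membered aromatic ring of carbon only and 9 heavy atoms cannot be told apart from the all-chain 1-pentylhexyl, with a 1.3-fold lower number from compound 3 to compound 4 (0.12 log units; within the scatter). Compound 4 also clears both other groups, with a 6.3-fold lower number from compound 1 to compound 4 (0.80 log units; beyond the scatter) and an 8.4-fold lower number from compound 2 to compound 4 (0.93 log units; beyond the scatter), so the low numbers here do not depend on two long alkyl arms. No measurement at hand accounts for these numbers. On these data alone, what a benzyl group would give on this nitrogen remains open, as does the effect of an amine on the phenyl ring.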